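Fluorine position on the aryl group of compound 1

This account rests on a few compounds, and the source may have more. Where it says the series, first, only, none or still open, it means among the compounds named here.

Compound 1 `O=C(Nc1ccc2sc(-c3ccccc3F)nc2c1)N1CCCCC1` is characterised in an ADME assay on HepG2 cells (Homo sapiens) for inhibition, read by resazurin assay, with a stated time of 48 h; a lower number here means that less compound is needed, a higher number that more compound is needed for the effect. In this assay compound 1 gives only a limit of the assay, > 50000 nM. Two further members of the series carry the same shared core. Compound 2 `O=C(Nc1ccc2sc(-c3ccccc3)nc2c1)c1cccs1` gives only a limit in this assay, > 50000 nM. Compound 3 `O=C(Nc1ccc2sc(-c3ccccc3)nc2c1)N1CCCC1` likewise gives only a limit in this assay, > 50000 nM. Within the data shown here, the single step between measured compounds that differ in one place, a step that the two limits leave unreadable from compound 2 to compound 3, stays unreadable because both ends sit at the limit of > 50000 nM in this assay, at which 3 of the 3 values shown sit.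

Compound 4 `O=C(Nc1ccc2sc(-c3cccc(F)c3)nc2c1)N1CCCCC1` differs from compound 1 by 3-fluorophenyl in place of 2-fluorophenyl on an aromatic carbon. Among the measured compounds shown here, no measured step moves the fluorine around the aryl ring, and no measured step in this assay yields a readable number at all; the only evidence is the limit of > 50000 nM in this assay, at which 3 of the 3 values shown sit. Nothing in the series therefore points to compound 4 leaving the limit.

Compound 4 is thus expected to give 50000 nM in this assay, with a range from 20000 nM to 150000 nM, and most likely again only a limit. The expected step from compound 1 to compound 4, a number no higher from compound 1 to compound 4 (the limit leaves the size open), is estimated as no change beyond the scatter.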

Compound 4, half-maximal effective concentration: > 50000 nM
Compound 4 gave a limit, no number (the forecaster's own chance of this, stated with the estimate: 85%); the middle value lies on the limit itself.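

In this assay compound 4 gives > 50000 nM, a limit of the assay and not a number. Compound 1 is also held at a limit, so no step from compound 1 to compound 4 can be read: the limit of > 50000 nM in this assay, at which 4 of the 4 values shown sit.

The compounds shown leave open whether any change on the shared core gives a readable number in this assay.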